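This account rests on a few compounds, and the source may have more. Where it says the series, first, only, none or still open, it means among the compounds named here.

In a functional assay on A549 cells (Homo sapiens) for cytotoxicity (a higher number here means a weaker inhibitor, a lower number a stronger inhibitor), three compounds have been measured: compound 1 `C=C/C=C\[C@H](C)[C@H](OC(N)=O)[C@@H](C)[C@H](O)[C@@H](C)C/C(C)=C\[C@H](C)[C@@H](O)[C@@H](C)/C=C\CCc1cccc(O)c1C` gives 910 nM, compound 2 `C=C/C=C\[C@H](C)[C@H](OC(N)=O)[C@@H](C)[C@H](O)[C@@H](C)C/C(C)=C\[C@H](C)[C@@H](O)[C@@H](C)/C=C\CCc1ccc(C)c(O)c1` gives 4000 nM and compound 3 `C=C/C=C\[C@H](C)[C@H](OC(N)=O)[C@@H](C)[C@H](O)[C@@H](C)C/C(C)=C\[C@H](C)[C@@H](O)[C@@H](C)/C=C\CCc1sccc1C` gives 790 nM. Compound 3 sits at the low end of these numbers, but within the scatter of its nearest neighbour, with a 1.2-fold lower number from compound 1 to compound 3 (0.06 log units; within the scatter). The other measured step to it is larger, a 5.1-fold lower number from compound 2 to compound 3 (0.70 log units; beyond the scatter).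

Compound 4 `C=C/C=C\[C@H](C)[C@H](OC(N)=O)[C@@H](C)[C@H](O)[C@@H](C)C/C(C)=C\[C@H](C)[C@@H](O)[C@@H](C)/C=C\CCc1ccccc1` carries phenyl in place of 3-methylthiophen-2-yl on a saturated chain carbon, two bonds along the chain from a double-bonded chain carbon. The three measured steps all exchange the aromatic group at this place, but none involves a plain phenyl, so none isolates this change. Their sizes run from none beyond the scatter to modest, the largest being a 5.1-fold lower number from compound 2 to compound 3 (0.70 log units; beyond the scatter), alongside a 4.4-fold higher number from compound 1 to compound 2 (0.64 log units; beyond the scatter). With compound 3 at the low end, the expected change leans upward, and a small step or none beyond the scatter is expected, a 1.9-fold higher number from compound 3 to compound 4 (0.28 log units; within the scatter). Compound 4 is estimated at 1500 nM, with an expected range of 500 nM to 5000 nM.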

Compound 4, half-maximal inhibitory concentration: 510 nM
Beside the measured number, compound 4's estimate is 2.9-fold (0.47 log units) above it, within the range that was stated.
By their numbers in this assay, from the lowest: compounds 4, 3 and 1 (each within the scatter of the next); then compound 2.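

In this assay plain phenyl on a saturated chain carbon, two bonds along the chain from a double-bonded chain carbon, stands level with 3-methylthiophen-2-yl (a 1.5-fold lower number from compound 3 to compound 4 (0.19 log units; within the scatter)) and with 3-hydroxy-2-methylphenyl (a 1.8-fold lower number from compound 1 to compound 4 (0.25 log units; within the scatter)), so neither a ring hydroxyl, a ring methyl nor the sulfur-containing ring is required to reach this range. For the compounds shown here, the one step here beyond the scatter (a 7.8-fold lower number from compound 2 to compound 4 (0.89 log units; beyond the scatter)) sets 3-hydroxy-4-methylphenyl apart from the other three groups and does not extend to ring substitution in general, as compound 1 goes against that reading. No available evidence bears on this result.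

The compounds shown do not separate the contributions of the hydroxyl and the methyl in 3-hydroxy-4-methylphenyl. Also open, as far as these compounds go, is whether a phenyl ring bearing an amine or a carboxylic acid, or a chain longer than the phenethyl of compound 4, would stay in this range.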